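This account rests on a few compounds, and the source may have more. Where it says the series, first, only, none or still open, it means among the compounds named here.

Compound 1 `COc1cc2c(cc1OC)C(c1ccc(Br)cc1)=NN(C)C(=S)C2`: 105 umol/kg
Compound 2 `COc1cc2c(cc1OC)C(c1ccc(Br)cc1)=NN=C(S)C2`: 52.1 umol/kg

Among the measured compounds shown here, in a functional assay on the whole organism with Mus musculus as the target (on this read-out higher numbers stand for an effect only at larger amounts of compound and lower numbers for an effect already at smaller amounts), compound 1 at 105 umol/kg and compound 2 at 52.1 umol/kg lie within the usual scatter of each other, so compound 1 stands level with the only other number available. Compound 3 `COc1cc2c(cc1OC)C(c1ccccc1)=NN(C)C(=S)C2` departs from compound 1 by one change: hydrogen in place of bromo on an aromatic carbon. For the measured compounds named here, no measured pair shows this change, so the data give no direction for it. The expected 1.2-fold lower number from compound 1 to compound 3 (0.07 log units; within the scatter) stays within the scatter. Compound 3 is estimated at 90 umol/kg, with an expected range of 35 umol/kg to 230 umol/kg.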

Compound 3, dose for half-maximal effect: 30.6 umol/kg
Compound 3: middle estimate off by 2.9-fold (0.47 log units), on the high side; measured number below the stated range.
By their numbers in this assay, from the lowest: compounds 3, 2 and 1 (each within the scatter of the next, the first and the last beyond it).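

In this assay, among the compounds shown here, there is a 3.4-fold lower number from compound 1 to compound 3 (0.54 log units; beyond the scatter) when hydrogen replaces bromo on the aromatic carbon para to a large group, the first reading of this position. With the rest of compound 1 unchanged, the 4-bromophenyl group is thus not needed for the effect at this dose level, and plain phenyl acts at smaller amounts. Nothing at hand explains this step. From the compounds shown here alone, whether the same change would act alike on compound 2 stays open. So does what a methoxy group or an amine would give at this place.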